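Three quiet neighbours and one rearranged side chain

The source may report more compounds than this note shows. Statements on the series, on what has been measured and on what is new or still open speak of the compounds shown alone.

In a functional assay on MC-38 cells (Mus musculus) for antiproliferative activity (a higher number here means a weaker inhibitor, a lower number a stronger inhibitor), compound 1 (`COc1ccc(S(=O)(=O)Nc2cccc3c(Cl)c[nH]c23)cc1`) gives 0.2 ug/mL and compound 2 (`NC(=O)c1ccc(S(=O)(=O)Nc2cccc3c(Cl)c[nH]c23)cc1`) gives 0.19 ug/mL on the same core. Compound 3 (`CS(=O)(=O)Nc1ccc(S(=O)(=O)Nc2cccc3c(Cl)c[nH]c23)cc1`) gives 0.26 ug/mL and so stands level with both, its gaps to them lying within the usual scatter. Compound 4 (`NS(=O)(=O)Cc1ccc(S(=O)(=O)Nc2cccc3c(Cl)c[nH]c23)cc1`) keeps the core and rearranges the same atoms in one place, with sulfamoylmethyl in place of methanesulfonamido on an aromatic carbon, para to a large group (sulfamoylmethyl in place of methanesulfonamido on an aromatic carbon). Three measured swaps at that same place bear on this. Carbamoyl for methoxy gave a 1.1-fold lower number from compound 1 to compound 2 (0.02 log units; within the scatter) while methanesulfonamido for methoxy gave a 1.3-fold higher number from compound 1 to compound 3 (0.11 log units; within the scatter) and methanesulfonamido for carbamoyl gave a 1.4-fold higher number from compound 2 to compound 3 (0.14 log units; within the scatter) in this assay as well. All three stayed inside the scatter, so no step beyond it is expected here. The estimate is a 1.2-fold lower number from compound 3 to compound 4 (0.07 log units; within the scatter) in this assay and that is no real change. For compound 4 the expected value is 0.22 ug/mL (estimated range 0.09 ug/mL to 0.5 ug/mL).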

Compound 4, half-maximal inhibitory concentration: 0.12 ug/mL
Compound 4: middle estimate off by 1.8-fold (0.26 log units), on the high side, within the range that was stated.
By their numbers in this assay, from the lowest: compounds 4, 2, 1 and 3 (each within the scatter of the next, the first and the last beyond it).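

In this assay the step of a 2.2-fold lower number from compound 3 to compound 4 (0.34 log units; beyond the scatter) is the only one at this position that lies beyond the scatter, and methanesulfonamido and sulfamoylmethyl hold the same atoms, so how those atoms are joined on this aromatic carbon can change the number even when their composition does not. The other two steps, a 1.6-fold lower number from compound 2 to compound 4 (0.20 log units; within the scatter) and a 1.7-fold lower number from compound 1 to compound 4 (0.22 log units; within the scatter), stay inside the scatter, so compound 4 stands level with compound 1 and compound 2 and is set apart only from compound 3. Nothing measured here explains why the rearrangement shifts the number.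

Still open, on these data alone, is whether the shift depends on the carbon link in sulfamoylmethyl or on the reversed order of its atoms. A plain sulfamoyl group or a longer chain such as sulfamoylethyl at this place would help separate the two.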